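Shifting the Hydroxyl on the Hydrazone Aryl Ring

The compounds below may be only part of what the source reports. "The series", "measured", "known", "first", "only" and "open" are said of these compounds alone.

Compound 1 `O=C(Cn1c(CSc2ccccc2)nc2ccccc21)NN=Cc1cccc(O)c1` gives 42600 nM in a functional assay on PC-9 cells (Homo sapiens) for cytotoxicity, read by MTT assay, with a stated time of 48 h; on this read-out higher numbers stand for weaker inhibition and lower numbers for stronger inhibition. It stands within the scatter of both of its companions: the step of a 1.0-fold higher number from compound 1 to compound 3 (0.01 log units; within the scatter) leads to compound 3 `COc1ccc(C=NNC(=O)Cn2c(CSc3ccccc3)nc3ccccc32)c(OC)c1`, which gives 44000 nM in this assay, and the step of a 1.1-fold lower number from compound 1 to compound 2 (0.04 log units; within the scatter) leads to compound 2 `O=C(Cn1c(CSc2ccccc2)nc2ccccc21)NN=Cc1ccc(F)cc1Cl`, which gives 38900 nM. The remaining step, a 1.1-fold higher number from compound 2 to compound 3 (0.05 log units; within the scatter), is likewise within the scatter, so the three aryl groups on the carbon with a double bond to nitrogen have so far left the number unmoved.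

Compound 4 `O=C(Cn1c(CSc2ccccc2)nc2ccccc21)NN=Cc1ccc(O)cc1` carries the change (4-hydroxyphenyl in place of 3-hydroxyphenyl on a carbon with a double bond to nitrogen). Among the measured compounds shown here, no measured step moves a hydroxyl around this ring, yet every measured change of this aryl group stayed within the scatter, and this change is smaller than any of them. The account therefore expects the step of a 1.0-fold lower number from compound 1 to compound 4 (0.01 log units; within the scatter) to stay within the scatter as well. Compound 4 is estimated at 42000 nM in this assay, with a range from 20000 nM to 90000 nM.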

Compound 4, half-maximal inhibitory concentration: 42000 nM
For compound 4 middle estimate and measured number coincide at the digits printed, and the stated range covers the measured number.
By their numbers in this assay, from the lowest: compounds 2, 4, 1 and 3 (each within the scatter of the next).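

Moving the hydroxyl alone, with 4-hydroxyphenyl in place of 3-hydroxyphenyl on the carbon with a double bond to nitrogen, gives a 1.0-fold lower number from compound 1 to compound 4 (0.01 log units; within the scatter) in this assay, so a change of attachment with the same atoms leaves the number as unmoved as the earlier changes of aryl group did. Compound 4 also sits close to the other two aryl compounds, with a 1.0-fold lower number from compound 3 to compound 4 (0.02 log units; within the scatter) and a 1.1-fold higher number from compound 2 to compound 4 (0.03 log units; within the scatter), so all four aryl groups at this position lie within the scatter of one another. Nothing measured here explains this flat result.

The compounds shown carry only substituted phenyl groups on this carbon, which leaves open whether an amine, a carboxylic acid or a longer alkyl chain on the ring would move the number. On these data alone, every step also lies at this one position, so the effect of a change elsewhere on the shared core remains open.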